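This account rests on a few compounds, and the source may have more. Where it says the series, first, only, none or still open, it means among the compounds named here.

The study concerns three compounds sharing one core, tested in a functional assay on cardiac atrium for agonist activity at histamine H2 receptor (Cavia porcellus); a higher number here means that more compound is needed for the effect, a lower number that less compound is needed. Compound 1 `CC(C)C(=O)/N=C(\N)NCCCc1c[nH]cn1` gives 110 nM in this assay, the lowest of the three numbers in hand. Compound 2 `N/C(=N\C(=O)CCCNC(=O)c1cc2ccccc2[nH]1)NCCCc1c[nH]cn1` gives 490 nM, and compound 3 `CN(CCC(=O)/N=C(\N)NCCCc1c[nH]cn1)C(=O)c1cc2ccccc2[nH]1` gives 3550 nM; both of these stand beyond the scatter above the value of compound 1. Within the data shown here, no pair of measured compounds differs in a single place, so the effect of any one change cannot be read directly from what has been measured.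

Compound 4 `CCC(=O)/N=C(\N)NCCCc1c[nH]cn1` has not yet been measured in this assay. It differs from compound 1 by hydrogen in place of methyl on a saturated chain carbon bound to a carbonyl carbon and a saturated chain carbon. Among the measured compounds shown here, nothing measured so far shows how this kind of change moves the number, so the expectation rests on its being a small change at a saturated chain carbon bound to a carbonyl carbon and a saturated chain carbon. The step is expected to be a 1.4-fold higher number from compound 1 to compound 4 (0.13 log units; within the scatter), not clearly beyond the scatter. Compound 4 is therefore estimated to give 150 nM in this assay, with a range from 60 nM to 400 nM.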

Compound 4, half-maximal effective concentration: 302 nM
Estimate against measurement, compound 4: 2.0-fold (0.30 log units) below; low and high end bracket the measured number.
By their numbers in this assay, from the lowest: compound 1; then compounds 4 and 2 (each within the scatter of the next); then compound 3.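

Among these compounds, the step gives the first reading of a single change: with hydrogen in place of methyl on a saturated chain carbon bound to a carbonyl carbon and a saturated chain carbon, that is, isopropyl to ethyl, this assay shows a 2.7-fold higher number from compound 1 to compound 4 (0.44 log units; beyond the scatter). The step is modest but beyond the scatter, so more compound is needed for the effect once this methyl is gone. Nothing in hand bears on why the number moves in this direction.

The compounds shown leave open whether a tert-butyl or a longer chain at this place would move the number further in either direction. They also leave open whether hydrogen in place of methyl would give a step of similar size on the longer chains of compound 2 and compound 3.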